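Chalcone series: ring change on the enone aryl

The source may report more compounds than this note shows. Statements on the series, on what has been measured and on what is new or still open speak of the compounds shown alone.

The shared core of compound 2 `O=C(/C=C/c1cccc(O)c1)c1cccc(-n2cc(-c3ccc(Cl)cc3)[nH]c2=O)c1` carries a 3-hydroxyphenyl on the enone and a chlorophenyl on the cyclic urea. For the measured compounds named here, in a functional assay on U-251 cells (Homo sapiens) for inhibition (a lower number here means a stronger inhibitor of growth, a higher number a weaker inhibitor of growth), compound 2 gives 580 nM, the lowest of the three numbers so far. Going by the values given here, compound 1 `O=C(/C=C/c1cccc(O)c1)c1cccc(-n2cc(-c3ccccc3)[nH]c2=O)c1`, the unsubstituted parent, gives 1610 nM; the single measured step, a 2.8-fold lower number from compound 1 to compound 2 (0.44 log units; beyond the scatter), is a modest one. Compound 3 `COc1ccc(-c2cn(-c3cccc(C(=O)/C=C/c4cc(OC)c(OC)c(OC)c4)c3)c(=O)[nH]2)cc1`, with methoxy groups on both aryl rings, gives 880 nM, which stands within the scatter of compound 2.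

Compound 4 `COc1cc(/C=C/C(=O)c2cccc(-n3cc(-c4ccc(Cl)cc4)[nH]c3=O)c2)ccc1O` keeps the chlorophenyl and changes the enone aryl: 4-hydroxy-3-methoxyphenyl in place of 3-hydroxyphenyl on a double-bonded chain carbon bound to a double-bonded chain carbon. Among the compounds with values here, no measured step touches this position directly. The only bearing is indirect: compound 3, which carries methoxy groups on this ring, and compound 2 give numbers that do not separate beyond the scatter, so the enone aryl looks tolerant of oxygen substitution in this small set. No step beyond the scatter is therefore expected in this assay; the estimated step of a 1.2-fold higher number from compound 2 to compound 4 (0.08 log units; within the scatter) is small. Compound 4 is estimated at 700 nM, with a range from 300 nM to 1700 nM.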

Compound 4, concentration for 50% growth inhibition: 2230 nM
For compound 4 the middle estimate is 3.2-fold (0.50 log units) below the measured one; measured number above the stated range.
By their numbers in this assay, from the lowest: compounds 2, 3, 1 and 4 (each within the scatter of the next, the first and the last beyond it).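

For the compounds shown here, with the chlorophenyl held constant, the enone aryl is not a silent position in this assay: 4-hydroxy-3-methoxyphenyl in place of 3-hydroxyphenyl gives a 3.8-fold higher number from compound 2 to compound 4 (0.58 log units; beyond the scatter), the first measured step at this position, and it runs towards weaker inhibition of growth. The two groups carry the same count of hydrogen-bond donors and differ in hydrogen-bond acceptors and heavy atoms, but this single pair cannot separate the contribution of the methoxy group from that of the changed hydroxyl placement, so oxygen substitution on this ring cannot be treated as generally tolerated when the rest of the molecule is fixed. Nothing among the data presented here gives a reason for the step.

Still open, going by these compounds, is whether a 4-hydroxyphenyl or a 3-methoxyphenyl on the enone would show a step of this size, which would assign it to one of the two changes. Also open, on these data alone, are how the same position responds to a different kind of group, such as an amine or a carboxylic acid, and whether the step holds when the chlorophenyl on the cyclic urea is replaced by an unsubstituted phenyl.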